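This account rests on a few compounds, and the source may have more. Where it says the series, first, only, none or still open, it means among the compounds named here.

Three measured compounds share one core and differ in the group on the sulfonyl sulfur and in the chain on the ring. Compound 1 `N#Cc1ccc(O[C@H]2CN(S(=O)(=O)c3ccc(C(F)(F)F)nc3)C[C@@]2(O)CO)cc1F` gives 31 mL/min/kg in an ADME assay on the whole organism (Rattus norvegicus, strain Sprague-Dawley) for pharmacokinetics, read by LC-MS, with a stated time of 30 min, at a dose of 1 mg/kg by the intravenous route; on this read-out lower numbers stand for slow clearance and higher numbers for fast clearance. Compound 2 `N#Cc1ccc(O[C@H]2CN(S(=O)(=O)c3ccc(Cl)cn3)C[C@@]2(O)CN)cc1F` gives 45 mL/min/kg in this assay, and compound 3 `N#Cc1ccc(O[C@H]2CN(S(=O)(=O)c3ccc(Cl)cc3Cl)C[C@@]2(O)CN)cc1F` gives 40 mL/min/kg. Compound 1 carries the lowest number of the three, but its gap to compound 3 and its gap to compound 2 are both within the scatter, so nothing separates these three in this assay.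

Compound 4 `N#Cc1ccc(O[C@H]2CN(S(=O)(=O)c3ccccc3C#N)C[C@@]2(O)CO)cc1F` has not been measured. It differs from compound 1 in one place: 2-cyanophenyl in place of 6-(trifluoromethyl)pyridin-3-yl on a sulfonyl sulfur.

Among the compounds with values here, only one measured step touches the group on the sulfonyl sulfur: a 1.1-fold lower number from compound 2 to compound 3 (0.05 log units; within the scatter). That step exchanged a six-membered aromatic ring with one hetero atom for a ring of carbon only and left the clearance unchanged within the scatter. Within the data shown here, no measured pair exchanges a trifluoromethyl for a nitrile, so that part of the change has no direct support. Because the step of a 1.1-fold lower number from compound 2 to compound 3 (0.05 log units; within the scatter) stayed within the scatter, compound 4 is expected to show a 1.1-fold higher number from compound 1 to compound 4 (0.03 log units; within the scatter) in this assay, a move within the scatter. The estimate for compound 4 in this assay is 33 mL/min/kg, with a range from 18 mL/min/kg to 60 mL/min/kg.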

Compound 4, clearance: 39 mL/min/kg
Beside the measured number, compound 4's estimate is 1.2-fold (0.07 log units) below it; the measured number falls inside the stated range.
By their numbers in this assay, from the lowest: compounds 1, 4, 3 and 2 (each within the scatter of the next).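

The exchange of 6-(trifluoromethyl)pyridin-3-yl for 2-cyanophenyl on a sulfonyl sulfur gives a 1.3-fold higher number from compound 1 to compound 4 (0.10 log units; within the scatter) in this assay and extends what was seen at this position. The earlier step at the sulfonyl sulfur came from compounds with a different chain on the ring and exchanged one chlorinated aromatic group for another, whereas this one keeps the chain of compound 1 and removes the three fluorine atoms and the ring nitrogen while adding a triple bond outside the ring. Both steps at this position now stay within the scatter, so among these four compounds neither aromatic exchange separates the clearance values, and nothing in the data shown explains this result or links it to any feature of these groups.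

The compounds shown leave open whether a group without an aromatic ring on the sulfonyl sulfur, such as a methyl or a cyclopropyl, or an aromatic group bearing a carboxylic acid, would also stay within the scatter. Within the data shown here, they also include no pair that differs only in the chain on the ring, so the part that chain plays in clearance cannot be read from them.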